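The source may report more compounds than this note shows. Statements on the series, on what has been measured and on what is new or still open speak of the compounds shown alone.

Measured so far:
- compound 1 `COc1ccc(-c2cc(N)c(C(=O)c3cc(OC)c(OC)c(OC)c3)s2)cc1OC`: 40 nM
- compound 2 `COc1cc(C(=O)c2sc(-c3ccccc3Cl)cc2N)cc(OC)c1OC`: 20 nM

Both values come from a functional assay on L1210 cells (Mus musculus) for antiproliferative activity; on this read-out lower numbers stand for stronger inhibition and higher numbers for weaker inhibition. Compound 1 has no clear rank in this assay, as its value lies within the scatter of the value for compound 2. Compound 3 `COc1cc(C(=O)c2sc(-c3cc(OC)c(OC)c(OC)c3)cc2N)cc(OC)c1OC` has not yet been measured. It differs from compound 1 by methoxy in place of hydrogen on an aromatic carbon. Among the compounds with values here, one measured step bears on this change, as it alters the same 3,4-dimethoxyphenyl group: a 2.0-fold lower number from compound 1 to compound 2 (0.30 log units; within the scatter), with 2-chlorophenyl in place of 3,4-dimethoxyphenyl. That step is only indirect evidence, as it involves a different substituent. Even so, replacing the whole group stayed within the scatter, so no step beyond the scatter is expected in this assay, and no direction is favoured. The expected step is a 1.1-fold higher number from compound 1 to compound 3 (0.05 log units; within the scatter). Compound 3 is estimated at 45 nM, with an expected range from 12 nM to 170 nM.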

Compound 3, half-maximal inhibitory concentration: 2300 nM
Beside the measured number, compound 3's estimate is 51-fold (1.71 log units) below it; the measured number lies above the stated range.
By their numbers in this assay, from the lowest: compounds 2 and 1 (each within the scatter of the next); then compound 3.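

Adding one methoxy in place of hydrogen, on an aromatic carbon ortho to a methoxy group, is a large change in this assay (a 58-fold higher number from compound 1 to compound 3 (1.76 log units; beyond the scatter)). The earlier step at the same aryl group, which exchanged the whole group for 2-chlorophenyl, stayed within the scatter (a 2.0-fold lower number from compound 1 to compound 2 (0.30 log units; within the scatter)), so that tolerance did not extend to this added methoxy. This position on the 3,4-dimethoxyphenyl group is therefore sensitive in this assay to a change of just this size. Nothing measured here accounts for the loss.

The compounds shown leave open whether the loss is specific to methoxy, or whether a fluorine or a hydroxyl on the same carbon would behave alike. They also leave open whether an ethoxy there would widen the loss further.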